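A few compounds are considered here, and "the series" means these few. Any claim that something is new, unique, unknown or untested is made for them only; others in the source may bear on it.

Compound 1 `Cc1cc(-c2ccc(C#N)cc2)cc(C)c1Nc1ccnc(Nc2ccc(C#N)cc2)n1`: 2080 nM
Compound 2 `Cc1cc(-c2ccc(F)cc2)cc(C)c1Nc1ccnc(Nc2ccc(C#N)cc2)n1`: 4170 nM

In an ADME assay on MT4 cells (Homo sapiens) for cytotoxicity, read by MTT assay, with a stated time of 4 days (on this read-out lower numbers stand for higher toxicity in this test and higher numbers for lower toxicity in this test), compound 2 gives 4170 nM. For the measured compounds named here, its only neighbour is compound 1, which gives 2080 nM, and the step of a 2.0-fold higher number from compound 1 to compound 2 (0.30 log units; within the scatter) lies within the scatter, so the two numbers cannot be told apart. Compound 3 `Cc1cc(-c2cccc(C(F)(F)F)c2)cc(C)c1Nc1ccnc(Nc2ccc(C#N)cc2)n1` is the next step on the same ring: 3-(trifluoromethyl)phenyl in place of 4-fluorophenyl on an aromatic carbon. Going by the values given here, the one measured step that bears on it is the swap of groups on that same ring between compound 1 and compound 2, a 2.0-fold higher number from compound 1 to compound 2 (0.30 log units; within the scatter), which stayed within the scatter. With only this to go on, the change from compound 2 to compound 3 is expected to give no step beyond the scatter in this assay, that is a 1.0-fold lower number from compound 2 to compound 3 (0.02 log units; within the scatter). Compound 3 is therefore estimated at 4000 nM, with a range from 1500 nM to 11000 nM.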

Compound 3, half-maximal cytotoxic concentration: 4030 nM
Compound 3: the middle estimate sits 1.0-fold (0.00 log units) below what was measured; measured number inside the range.
By their numbers in this assay, from the lowest: compounds 1, 3 and 2 (each within the scatter of the next).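

In this assay, replacing the 4-fluorophenyl group with 3-(trifluoromethyl)phenyl leaves the reading unchanged within the scatter (a 1.0-fold lower number from compound 2 to compound 3 (0.01 log units; within the scatter)), and the comparison with the 4-cyanophenyl group also stays within it (a 1.9-fold higher number from compound 1 to compound 3 (0.29 log units; within the scatter)). The earlier pair varied only the group at the 4-position of the outer phenyl ring, whereas compound 3 changes the group, its place on that ring and the heavy-atom count together, and still cannot be told apart from compound 1 or compound 2. No measurement here accounts for this lack of separation.

From the compounds shown here alone, because both the group and its place changed at once, the effect of each alone remains unknown, and 4-(trifluoromethyl)phenyl would separate them. Going by these compounds, it also remains open whether replacing the phenyl ring with an amine, a carboxylic acid or a longer chain would move the reading beyond the scatter.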